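This account rests on a few compounds, and the source may have more. Where it says the series, first, only, none or still open, it means among the compounds named here.

In an ADME assay on BJ cells (Homo sapiens) for cytotoxicity, with a stated time of 72 h (a higher number here means that more compound is needed for the effect, a lower number that less compound is needed), compound 2 `COc1ccc(NC(=O)Nc2cc(C)nc3ccccc23)cc1OC` gives only a limit, > 25000 nM, and not a number. Compound 1 `Cc1cc(NC(=O)Nc2ccc(Cl)c(Cl)c2)c2ccccc2n1`, which also bears chloro, gives a measured 23000 nM. Compound 3 `COc1ccc(NC(=O)Nc2cc(C)nc3ccccc23)cc1Cl` differs from compound 2 by chloro in place of methoxy on an aromatic carbon. Within the data shown here, no measured step shows this change, so the expectation rests on the value of compound 1 at 23000 nM. The expected step, an at least 1.0-fold lower number from compound 2 to compound 3 (0.03 log units; that floor lies within the scatter), is none beyond the scatter in this assay. Compound 3 is estimated at 23000 nM, within an expected range of 11000 nM to 40000 nM.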

Compound 3, half-maximal effective concentration in the BJ assay: 23000 nM
Compound 3: the middle estimate sits on the measured number at the digits printed; low and high end bracket the measured number.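

In the BJ assay, chloro in place of methoxy on an aromatic carbon gives an at least 1.0-fold lower number from compound 2 to compound 3 (0.03 log units; that floor lies within the scatter), while methoxy in place of chloro on an aromatic carbon gives no change at the digits printed from compound 1 to compound 3 (within the scatter), with compound 3 at 23000 nM, so neither step separates these compounds beyond the scatter. In the BJ assay compound 2 gives > 25000 nM, a limit and not a number, and the first of these steps starts from it: the limit of > 25000 nM in the BJ assay, at which 1 of the 3 values shown sits. The same exchange does separate the pair in a physicochemical assay for solubility, at pH 7.4 (on this read-out lower numbers stand for lower solubility and higher numbers for higher solubility), with a 10-fold lower number from compound 2 to compound 3 (1.01 log units; beyond the scatter). In the physicochemical assay compound 2 gives 4100 nM and compound 3 gives 400 nM.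

As far as these compounds go, how large the step in the BJ assay really is stays open, as compound 2 has only a limit there. Also open, from the compounds shown here alone, is how an amine or a carboxylic acid at this place would read in the BJ assay or in the physicochemical assay.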